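Trimming the amide side group of a weak inhibitor

This account rests on a few compounds, and the source may have more. Where it says the series, first, only, none or still open, it means among the compounds named here.

In a functional assay on HepG2 cells (Homo sapiens) for inhibition, read by MTT assay, with a stated time of 120 h (on this read-out lower numbers stand for stronger inhibition and higher numbers for weaker inhibition), compound 3 `CC(NC(=O)C#Cc1ccc(NC(=O)Nc2ccc(Cl)c(C(F)(F)F)c2)cc1)c1ccccc1` gives 20500 nM. Compound 2 `CC(NC(=O)C#Cc1ccc(NC(=O)Nc2cc(C(F)(F)F)ccc2Cl)cc1)c1ccccc1` gives 19000 nM, and the step of a 1.1-fold higher number from compound 2 to compound 3 (0.03 log units; within the scatter) leaves these two compounds level. Compound 1 `C/C(=C\c1ccc(NC(=O)Nc2ccc(Cl)c(C(F)(F)F)c2)cc1)C(=O)NC(C)c1ccccc1` gives > 50000 nM, which is a limit of the assay and not a number.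

Compound 4 `CNC(=O)C#Cc1ccc(NC(=O)Nc2ccc(Cl)c(C(F)(F)F)c2)cc1` carries methyl in place of 1-phenylethyl on an amide-type nitrogen. Within the data shown here, the one measured step changes a different part of the molecule, so it offers no direct guide and the expectation stays loose. A modest move towards weaker inhibition is expected, with an estimated change of a 1.7-fold higher number from compound 3 to compound 4 (0.23 log units; within the scatter). For compound 4 the expected value is 35000 nM, with an estimated range from 14000 nM to 90000 nM.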

Compound 4, half-maximal inhibitory concentration: 23300 nM
Compound 4: middle estimate off by 1.5-fold (0.18 log units), on the high side, and the stated range covers the measured number.
By their numbers in this assay, from the lowest: compounds 2, 3 and 4 (each within the scatter of the next). At a limit, above all of these: compound 1.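

In this assay, replacing 1-phenylethyl with methyl on the amide-type nitrogen gives a 1.1-fold higher number from compound 3 to compound 4 (0.06 log units; within the scatter). The aromatic ring of that side group is therefore not needed to hold the number where it stands, something compounds 1, 2 and 3, which all carry 1-phenylethyl, could not show. Nothing measured here gives a reason for this flat result.

On these data alone, whether an amine, a carboxylic acid or a longer chain on this nitrogen would shift the number remains open. So does whether any group at this position can bring stronger inhibition.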